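The source may hold more compounds than are shown below. What is called first, only, known or untested is meant among the compounds shown, and "the series" means these compounds.

Going by the values given here, compound 1 `COc1ccc(COc2cc(O)c3c(=O)cc(C)oc3c2[C@H]2CCN(C)C[C@H]2O)cc1` and compound 2 `CCN(CC)Cc1c(O)c([C@H]2CCN(C)C[C@H]2O)c2oc(C)cc(=O)c2c1O` are the two measured members of the set. In a functional assay on MCF7 cells (Homo sapiens) for inhibition, read by MTT assay, with a stated time of 48 h, tested at 10 uM (on this read-out lower numbers stand for less inhibition of growth and higher numbers for more inhibition of growth at the one concentration tested), compound 1 gives 16%. In this assay compound 2 gives 24%, the higher of the two numbers, though compound 1 lies within the scatter of it, so no order between them is claimed. Compound 3 `Cc1cc(=O)c2c(O)c(CN3CCCCC3)c(O)c([C@H]3CCN(C)C[C@H]3O)c2o1` differs from compound 2 by piperidin-1-yl in place of diethylamino on a saturated chain carbon bound to an aromatic carbon. Among the compounds with values here, no measured pair shows this change, so in this assay the expected step is small, none beyond the scatter: no change at the digits printed from compound 2 to compound 3 (within the scatter) is the estimate. Compound 3 is thus expected to give 24%, with a range from 8% to 42%.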

Compound 3, percent growth inhibition at one concentration: 15%
For compound 3 the middle estimate is 9 percentage points above the measured one; measured number inside the range.
By their numbers in this assay, from the lowest: compounds 3, 1 and 2 (each within the scatter of the next).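

this assay: piperidin-1-yl in place of diethylamino on a saturated chain carbon bound to an aromatic carbon gives a number 9 percentage points lower from compound 2 to compound 3 (within the scatter). Going by these compounds alone, this is the first measured pair at this place, and it shows that this change of amine, which adds a six-membered non-aromatic ring, does not move the read-out beyond the scatter. No evidence on the reason for this result is available. Still open, from the compounds shown here alone, is whether morpholin-4-yl, a carboxylic acid or a longer chain carrying the amine at this place would give a step beyond the scatter.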